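Working notes: replacing the carboxylated amine in compound 2

The source may report more compounds than this note shows. Statements on the series, on what has been measured and on what is new or still open speak of the compounds shown alone.

Measured in a functional assay on MIA PaCa-2 cells (Homo sapiens) for inhibition, read by MTT assay, with a stated time of 48 h, tested at 10 uM; a lower number here means less inhibition of growth, a higher number more inhibition of growth at the concentration tested:
compound 1 `Cc1cc(=O)c2c(O)c(CN3CCCC3)c(O)c([C@H]3CCN(C)C[C@H]3O)c2o1`: 28%
compound 2 `Cc1cc(=O)c2c(O)c(CN3CCCC3C(=O)O)c(O)c([C@H]3CCN(C)C[C@H]3O)c2o1`: 10%

Of the two measured compounds, compound 2 has the lower number, at 10% in this assay. The next compound, compound 3 `Cc1cc(=O)c2c(O)c(CN3CCCCC3)c(O)c([C@H]3CCN(C)C[C@H]3O)c2o1`, has not yet been measured. It carries piperidin-1-yl in place of 2-carboxypyrrolidin-1-yl on a saturated chain carbon bound to an aromatic carbon.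

For the measured compounds named here, only one measured step bears on this change: a number 18 percentage points lower from compound 1 to compound 2 (beyond the scatter). That step is modest but beyond the scatter, and it places carboxy in place of hydrogen on a saturated ring carbon. The change to compound 3 also removes the carboxy, so a step of similar size in the opposite direction is the reasonable expectation. Going by the values given here, no measured step covers the change in ring size, which leaves the estimate wide. In this assay, the expected change is a number 18 percentage points higher from compound 2 to compound 3 (beyond the scatter), towards more inhibition of growth. The estimated value for compound 3 is 28%, with an expected range of 12% to 45%.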

Compound 3, percent growth inhibition at one concentration: 14%
Compound 3: middle estimate off by 14 percentage points, on the high side, and the stated range covers the measured number.
By their numbers in this assay, from the lowest: compounds 2 and 3 (each within the scatter of the next); then compound 1.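

In this assay, exchanging 2-carboxypyrrolidin-1-yl for piperidin-1-yl on a saturated chain carbon bound to an aromatic carbon gives a number 4 percentage points higher from compound 2 to compound 3 (within the scatter), so removing the carboxy group in this exchange does not by itself return the number seen with compound 1. The change from pyrrolidin-1-yl to piperidin-1-yl, with no carboxy group on either side, gives a number 14 percentage points lower from compound 1 to compound 3 (beyond the scatter), which shows that the read-out at this position responds to the ring of the amine as well as to the carboxy group. Nothing available explains why either change alters growth inhibition at the concentration tested.

The compounds shown leave open whether a carboxy group on piperidin-1-yl would move the number as it does on pyrrolidin-1-yl, and so whether the two changes act independently at this position. Also open, as far as these compounds go, is how this assay would respond to a morpholin-4-yl group or an open-chain amine such as dimethylamino at this place, which would test whether pyrrolidin-1-yl is specifically favoured among the amines.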